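Benzylamine arm variations on the shared core

The source may report more compounds than this note shows. Statements on the series, on what has been measured and on what is new or still open speak of the compounds shown alone.

Measured compounds in a functional assay on DLD-1 cells (Homo sapiens) for inhibition, read by MTT assay, with a stated time of 72 h; a lower number here means a stronger inhibitor, a higher number a weaker inhibitor:
Compound 1, `COc1cc(Oc2cccc(Nc3ccccc3)c2)cc(OC)c1CNCc1ccc(Br)cc1`, gives 3520 nM.
Compound 2, `COc1cc(Oc2cccc(Nc3ccccc3)c2)cc(OC)c1CNCc1ccc(C)cc1`, gives 6080 nM.
Compound 3, `COc1ccc(CCCNCc2c(OC)cc(Oc3cccc(Nc4ccccc4)c3)cc2OC)cc1`, gives 2540 nM.

Compound 1 stands second highest of the three numbers. Its nearest neighbour is compound 3, reached by a 1.4-fold lower number from compound 1 to compound 3 (0.14 log units; within the scatter); the furthest is compound 2, reached by a 1.7-fold higher number from compound 1 to compound 2 (0.24 log units; within the scatter). Both of these steps stay within the scatter. Among the measured compounds shown here, the only step beyond the scatter is a 2.4-fold lower number from compound 2 to compound 3 (0.38 log units; beyond the scatter), and it exchanges the whole arm on the amine nitrogen rather than a single substituent.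

Compound 4, `COc1cc(Oc2cccc(Nc3ccccc3)c2)cc(OC)c1CNCc1ccc(O)cc1`, differs from compound 1 by hydroxy in place of bromo on an aromatic carbon. For the measured compounds named here, no measured step exchanges bromo for hydroxy anywhere. The step that bears most closely on it is a 1.7-fold higher number from compound 1 to compound 2 (0.24 log units; within the scatter), which alters the same aromatic carbon and stays within the scatter. The larger exchange of the arm in a 1.4-fold lower number from compound 1 to compound 3 (0.14 log units; within the scatter) also stays within the scatter. Going by these compounds, the expectation is therefore a step of no more than the scatter, a 1.2-fold higher number from compound 1 to compound 4 (0.08 log units; within the scatter), with the range widened because the entering group is untested here. Compound 4 is estimated at 4200 nM, expected to fall between 1800 nM and 10000 nM.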

Compound 4, half-maximal inhibitory concentration: 2690 nM
Beside the measured number, compound 4's estimate is 1.6-fold (0.19 log units) above it; the measured number falls inside the stated range.
By their numbers in this assay, from the lowest: compounds 3, 4, 1 and 2 (each within the scatter of the next, the first and the last beyond it).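

In this assay, hydroxy, which carries a hydrogen-bond donor and acceptor where bromo has neither, gives a 1.3-fold lower number from compound 1 to compound 4 (0.12 log units; within the scatter) on this aromatic carbon, so this exchange does not separate the two groups. Against methyl on the same carbon, the result is a 2.3-fold lower number from compound 2 to compound 4 (0.35 log units; beyond the scatter), a modest step, yet a 1.7-fold higher number from compound 1 to compound 2 (0.24 log units; within the scatter) shows that bromo and methyl are not separated, so the three groups do not form a clean order and only the methyl-hydroxy pair stands apart. The series now also shows that a simple 4-hydroxybenzyl arm matches the longer arm of compound 3, with a 1.1-fold higher number from compound 3 to compound 4 (0.02 log units; within the scatter) leaving the two arms unresolved despite the larger change in structure.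

Nothing available bears on why the numbers fall as they do. Open, going by these compounds, is whether an amine, a carboxylic acid or a methoxy group on this aromatic carbon would stay with the hydroxy and bromo compounds or fall nearer to compound 2, and whether hydroxy in place of methoxy on the longer arm of compound 3 would shift its number.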